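The source may hold more compounds than are shown below. What is called first, only, known or untested is meant among the compounds shown, and "the series" means these compounds.

Of the compounds shown here, two have so far been measured in an assay on cells for activation of Cystic fibrosis transmembrane conductance regulator (Homo sapiens), read by fluorescence, with stated times of 10 min and 12 s; a lower number here means that less compound is needed, a higher number that more compound is needed for the effect. Compound 1 `CCN(CC)c1nc(Nc2cccc(F)c2)nc(OCC(F)(F)C(F)F)n1` gives 1600 nM, and compound 2 `CCN(CC)c1nc(Nc2cccc([N+](=O)[O-])c2)nc(OCC(F)(F)C(F)F)n1` gives 1200 nM. Among the measured compounds shown here, the single step between them, a 1.3-fold lower number from compound 1 to compound 2 (0.12 log units; within the scatter), shows that putting a nitro in place of the fluoro on the aromatic carbon left the number where it was, within the scatter. Compound 2 therefore stands at the lower of the two numbers, but its distance from compound 1 is within the scatter, so the two cannot be ranked.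

Compound 3 `CCN(CC)c1nc(Nc2ccc(F)cc2)nc(OCC(F)(F)C(F)F)n1` awaits measurement. It differs from compound 2 by 4-fluorophenyl in place of 3-nitrophenyl on a nitrogen on an aromatic ring. For the measured compounds named here, the only measured step that bears on this change is the one from compound 1 to compound 2, and it was within the scatter; no measured pair shows a 4-fluorophenyl at this place. The expected step is accordingly a 1.3-fold higher number from compound 2 to compound 3 (0.10 log units; within the scatter), one of no change beyond the scatter, with compound 1 as the nearest guide. Compound 3 is estimated at 1500 nM, with a range from 600 nM to 4000 nM.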

Compound 3, half-maximal effective concentration: 4800 nM
Compound 3: the middle estimate sits 3.2-fold (0.51 log units) below what was measured, and the stated range ends below it.
By their numbers in this assay, from the lowest: compounds 2 and 1 (each within the scatter of the next); then compound 3.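

In this assay, the group on the nitrogen on the aromatic ring now proves able to move the number beyond the scatter, which the earlier pair had not shown: 4-fluorophenyl in place of 3-nitrophenyl gives a clear rise (a 4.0-fold higher number from compound 2 to compound 3 (0.60 log units; beyond the scatter)). The same holds when only the fluoro's place on the phenyl differs, as 4-fluorophenyl in place of 3-fluorophenyl also gives a rise beyond the scatter (a 3.0-fold higher number from compound 1 to compound 3 (0.48 log units; beyond the scatter)), so among these three compounds the number follows where the substituent sits as well as, or more than, which substituent it is. Nothing measured independently of this assay accounts for the rise.

The three compounds leave open whether the higher number belongs to the 4-fluorophenyl alone or would also appear with other groups at that place on the ring, and a plain phenyl, a methoxy or an amine there would help to separate the two readings. They also say nothing about how the diethylamino group or the fluorinated chain on oxygen contributes, since both stay the same throughout.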